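The source may report more compounds than this note shows. Statements on the series, on what has been measured and on what is new or still open speak of the compounds shown alone.

Working notes on the series. For the measured compounds named here, in a functional assay on MCF7 cells (Homo sapiens) for inhibition, read by MTT assay, with a stated time of 72 h (a higher number here means a weaker inhibitor of growth, a lower number a stronger inhibitor of growth), compound 3 `CN(CCCNS(=O)(=O)c1cc(C(F)(F)F)cc(C(F)(F)F)c1)Cc1ccccc1` stands highest of the three numbers so far, at 16000 nM. Compound 2 `COc1ccc(CNCCCNS(=O)(=O)c2cc(C(F)(F)F)cc(C(F)(F)F)c2)cc1OC` gives 1900 nM in this assay, a lower number beyond the scatter, and compound 1 `O=S(=O)(NCCNCc1ccc(-c2ccccc2)cc1)c1cc(C(F)(F)F)cc(C(F)(F)F)c1` gives 1400 nM, also lower beyond the scatter. Going by the values given here, no two of the measured compounds differ in only one place, so no single step within the measured set can be isolated; compounds 1 and 2 each differ from compound 3 in more than one respect.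

Compound 4 `COc1ccc(CNCCCNS(=O)(=O)c2cc(C(F)(F)F)cc(C(F)(F)F)c2)cc1` differs from compound 3 by (4-methoxybenzyl)amino in place of benzyl(methyl)amino on a saturated chain carbon, three bonds along the chain from a sulfonamide nitrogen. Compound 4 thereby comes to resemble compound 2 closely in chain, core and the amine bearing a hydrogen-bond donor, and compound 2 gives 1900 nM in this assay. On that basis the step from compound 3 to compound 4 is expected to be downward and beyond the scatter, with a 6.4-fold lower number from compound 3 to compound 4 (0.81 log units; beyond the scatter) as the estimated size. Compound 1, which also carries a hydrogen-bond donor at the amine, gives 1400 nM, consistent with the same direction. For compound 4 the expected value in this assay is 2500 nM, with a range of 1000 nM to 6500 nM.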

Compound 4, concentration for 50% growth inhibition: 2500 nM
The estimate for compound 4 equals the measured number at the digits printed, and the stated range covers the measured number.
By their numbers in this assay, from the lowest: compounds 1, 2 and 4 (each within the scatter of the next); then compound 3.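

In this assay the series now has its first step that can be read at one place: (4-methoxybenzyl)amino in place of benzyl(methyl)amino on a saturated chain carbon, three bonds along the chain from a sulfonamide nitrogen, gives a 6.4-fold lower number from compound 3 to compound 4 (0.81 log units; beyond the scatter) and so the number at this position does respond to the amine group it carries. Hydrogen in place of methoxy on an aromatic carbon gives a 1.3-fold higher number from compound 2 to compound 4 (0.12 log units; within the scatter) and this methoxy therefore does not separate the two compounds in this assay. No measurement is available that bears on the reason for either step.

The step to compound 4 still joins two differences, a hydrogen in place of the methyl on the amine nitrogen and a methoxy on the aromatic ring, and the compounds shown do not tell which of them carries the change. On these data alone, a plain benzylamino group or a (4-methoxybenzyl)(methyl)amino group at the same position would part the two, and whether the same step holds on a longer chain remains open.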